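Defining the ring stereocentres of a cinnamaldehyde-bearing neolignan

A few compounds are considered here, and "the series" means these few. Any claim that something is new, unique, unknown or untested is made for them only; others in the source may bear on it.

Two related compounds have been tested in a functional assay on Hep 3B2 cells (Homo sapiens) for cytotoxicity, read by MTT assay, with a stated time of 48 h; on this read-out higher numbers stand for weaker inhibition and lower numbers for stronger inhibition. Compound 1, `COc1cc([C@@H]2Oc3c(OC)cc(/C=C/C=O)cc3[C@H]2CO)cc(OC)c1O`, carries an extra methoxy group on its pendant aromatic ring and has both ring stereocentres drawn with fixed configurations; in this assay compound 1 gives 60700 nM. Compound 2, `COc1cc(C2Oc3c(OC)cc(/C=C/C=O)cc3C2CO)ccc1O`, lacks that extra methoxy group and is drawn without configurations at its two ring stereocentres; in this assay compound 2 gives 29300 nM. Compound 2 thus stands at the lowest of the two numbers, and the gap to compound 1 lies beyond the usual scatter of this assay.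

Compound 3, `COc1cc([C@@H]2Oc3c(OC)cc(/C=C/C=O)cc3[C@H]2CO)ccc1O`, is the next compound to be measured in this assay. It differs from compound 2 only in how the stereochemistry is drawn: the two compounds have the same atoms and bonds; at least one stereo element is drawn with a configuration in one of them and without one in the other: 2 of 3 stereo elements differ; a stereocentre at a saturated ring carbon is drawn without a configuration in compound 2 and R in compound 3; a stereocentre at a saturated ring carbon is drawn without a configuration in compound 2 and S in compound 3

Going by the values given here, no step between two measured compounds resolves the same configuration, so there is nothing to size this change against. Among the compounds with values here, compound 2 gives 29300 nM in this assay, and no measured pair here separates configurations at the ring carbons. Compound 3 is therefore expected to land near the number of compound 2, with the step of a 1.1-fold lower number from compound 2 to compound 3 (0.05 log units; within the scatter) taken as within the scatter; the expected value is 26000 nM, with a range from 9000 nM to 75000 nM.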

Compound 3, half-maximal inhibitory concentration: 31500 nM
Beside the measured number, compound 3's estimate is 1.2-fold (0.08 log units) below it, and the stated range covers the measured number.
By their numbers in this assay, from the lowest: compounds 2, 3 and 1 (each within the scatter of the next, the first and the last beyond it).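

In this assay, drawing both ring stereocentres with fixed configurations brings no change that stands out from the scatter, with a 1.1-fold higher number from compound 2 to compound 3 (0.03 log units; within the scatter). Compound 1 and compound 3 share those drawn configurations and differ only in the extra methoxy group on the pendant aromatic ring, and this single change also stays within the scatter, with a 1.9-fold lower number from compound 1 to compound 3 (0.28 log units; within the scatter). The first of these two comparisons needs a cautious reading, since a drawing without configurations does not tell which arrangement is present in the sample, and all that separates the pair is this: the fact that one of compounds 2 and 3 is drawn with a defined configuration and the other without, at the place where they differ

Going by these compounds, only one defined arrangement of the two ring stereocentres appears here, so it remains open whether the opposite configuration at either ring carbon would give a clearly different number. Also open, on these data alone, is how the number would respond to larger changes to the core of compound 3, such as a carboxylic acid in place of the aldehyde or an amine in place of the hydroxyl group of the hydroxymethyl arm.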